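Fluoro to nitro on the pendant phenyl: working notes

This account rests on a few compounds, and the source may have more. Where it says the series, first, only, none or still open, it means among the compounds named here.

compound 1 `Cc1ccccc1Cn1cc(COc2ccc3c(=O)ccoc3c2)nn1` in a functional assay on QGY7701 cells (Homo sapiens) for cytotoxicity, read by MTT assay, with a stated time of 48 h; on this read-out higher numbers stand for weaker inhibition and lower numbers for stronger inhibition: > 100000 nM, a limit of the assay.
compound 2 `O=c1ccoc2cc(OCc3cn(Cc4cccc(F)c4)nn3)ccc12` in this assay : > 100000 nM, also a limit.

Compound 2 stands at the limit of > 100000 nM in this assay, at which 2 of the 2 values shown sit; its value is not a number. Among the compounds with values here, the only measured step, a step that the two limits leave unreadable from compound 1 to compound 2, has no readable size. Compound 3 `O=c1ccoc2cc(OCc3cn(Cc4cccc([N+](=O)[O-])c4)nn3)ccc12` differs from compound 2 by nitro in place of fluoro on an aromatic carbon. Within the data shown here, no measured step bears on this change, so the expectation rests on compound 2 alone at the limit of > 100000 nM in this assay, at which 2 of the 2 values shown sit. The step that the limit leaves unreadable from compound 2 to compound 3 is expected to be none beyond the scatter, with another limit the likeliest outcome. Compound 3 is estimated at 120000 nM, between 40000 nM and 400000 nM.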

Compound 3, half-maximal inhibitory concentration: 14100 nM
For compound 3 the middle estimate is 8.5-fold (0.93 log units) above the measured one; measured number below the stated range.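

In this assay, nitro in place of fluoro gives an at least 7.0-fold lower number from compound 2 to compound 3 (0.85 log units; beyond the scatter), and 3-nitrophenyl in place of 2-methylphenyl gives an at least 7.0-fold lower number from compound 1 to compound 3 (0.85 log units; beyond the scatter). Compound 3 alone has a readable number, so the group on this aromatic carbon of the pendant phenyl can decide whether a value is read at all: the limit of > 100000 nM in this assay, at which 2 of the 3 values shown sit.

From the compounds shown here alone, the full size of both steps stays open, as the limit fixes only how small they can be. Also open, going by these compounds, is whether an amine or a nitrile at this place would give a readable number too.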